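The source may hold more compounds than are shown below. What is called first, only, known or untested is meant among the compounds shown, and "the series" means these compounds.

Measured compounds in a functional assay on MCF7 cells (Homo sapiens) for antiproliferative activity, read by MTT assay, with a stated time of 72 h; on this read-out higher numbers stand for weaker inhibition and lower numbers for stronger inhibition:
- compound 1, `CCN1CCN(c2cc(C)c3cc(NC(=O)c4ccccc4F)ccc3n2)CC1`: 32600 nM
- compound 2, `Cc1cc(NCCN2CCN(C)CC2)nc2ccc(NC(=O)c3ccc(Cl)c(Cl)c3)cc12`: 1700 nM
- compound 3, `Cc1cc(N2CCN(C)CC2)nc2ccc(NC(=O)c3ccc(Cl)c(Cl)c3)cc12`: 3000 nM

Among these three, compound 1 gives the highest number, so it is the weakest inhibitor of the set; compound 3 is its nearest neighbour and compound 2 the furthest, both separated from it by more than the usual scatter. For the measured compounds named here, the one single-point step available, a 1.8-fold higher number from compound 2 to compound 3 (0.25 log units; within the scatter), concerns the group on an aromatic carbon of the shared core and lies within the scatter; it says nothing about the amide end of the molecule.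

Compound 4, `CCN1CCN(c2cc(C)c3cc(NC(=O)c4cccc(Br)c4)ccc3n2)CC1`, is not yet measured. It differs from compound 1 in one place: 3-bromophenyl in place of 2-fluorophenyl on a carbonyl carbon. Going by the values given here, no measured pair isolates this change, so there is no direct precedent. Compounds 2 and 3 carry a different halogenated aryl group on the carbonyl carbon and give much lower numbers than compound 1, but each also differs from compound 1 elsewhere, so only their values, not a clean step, can be taken from them.

On that basis a modest move toward a lower number is expected for compound 4, a 2.7-fold lower number from compound 1 to compound 4 (0.43 log units; beyond the scatter), with the estimate 12000 nM and a range from 3500 nM to 40000 nM.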

Compound 4, half-maximal inhibitory concentration: 11600 nM
Compound 4: the middle estimate sits 1.0-fold (0.01 log units) above what was measured; low and high end bracket the measured number.
By their numbers in this assay, from the lowest: compounds 2 and 3 (each within the scatter of the next); then compound 4; then compound 1.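

In this assay, replacing 2-fluorophenyl with 3-bromophenyl on the carbonyl carbon, with the rest of the molecule unchanged, gives a 2.8-fold lower number from compound 1 to compound 4 (0.45 log units; beyond the scatter). For the compounds shown here, this is a modest step, but it is the first in this set to isolate the aryl group at the amide end of the molecule, and it shows that a change there alone can move the number by more than the scatter. The earlier step, a 1.8-fold higher number from compound 2 to compound 3 (0.25 log units; within the scatter), concerned a different part of the molecule and stayed within the scatter, while nothing available here explains why this new change lowers the number.

The groups 2-fluorophenyl and 3-bromophenyl differ both in their halogen and in where it sits on the ring, so this single step cannot show which of those two differences accounts for the change. The compounds shown also leave open how a plain phenyl group with no halogen would compare on the same carbonyl carbon, or a phenyl group carrying an amine or a carboxylic acid.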